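Para-halogen swap on the sulfonamide aryl of compound 3

A few compounds are considered here, and "the series" means these few. Any claim that something is new, unique, unknown or untested is made for them only; others in the source may bear on it.

Measured in an assay on MDA-MB-231 cells for displacement of a labelled ligand from C-X-C chemokine receptor type 4 (Homo sapiens), read by fluorescence and microscopy, with stated times of 10 min and 30 min; a lower number here means that less compound is needed, a higher number that more compound is needed for the effect:
compound 1 `COc1ccccc1C(=O)NCc1ccc(CNS(=O)(=O)c2cccc(Cl)c2)cc1`: 1000 nM
compound 2 `COc1ccccc1C(=O)NCc1ccc(CNS(=O)(=O)c2cccc(F)c2)cc1`: 1000 nM
compound 3 `COc1ccccc1C(=O)NCc1ccc(CNS(=O)(=O)c2ccc(F)cc2)cc1`: 100 nM

Compound 3 stands lowest of the three in this assay, beyond the scatter from both others: a 10-fold lower number from compound 1 to compound 3 (1.00 log units; beyond the scatter) and a 10-fold lower number from compound 2 to compound 3 (1.00 log units; beyond the scatter). Both of these steps move the halogen from the 3-position to the 4-position of the sulfonyl aryl ring, and the identity of the halogen does not seem to matter at the 3-position, since no change at the digits printed from compound 1 to compound 2 (within the scatter).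

Compound 4 `COc1ccccc1C(=O)NCc1ccc(CNS(=O)(=O)c2ccc(Cl)cc2)cc1` keeps the 4-substitution of compound 3 and changes only the halogen: chloro in place of fluoro on an aromatic carbon. Among the measured compounds shown here, the only measured step that bears on this change, the exchange of chloro for fluoro on the aryl carbon in no change at the digits printed from compound 1 to compound 2 (within the scatter), lies within the scatter. The same exchange at the 4-position is therefore expected to give no step beyond the scatter in this assay, in either direction. Compound 4 is estimated at 100 nM, with a range from 40 nM to 250 nM. The expected step is no change at the digits printed from compound 3 to compound 4 (within the scatter).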

Compound 4, effective concentration (reported as EC, without a stated level of effect): 1000 nM
Estimate against measurement, compound 4: 10-fold (1.00 log units) below; the measured number lies above the stated range.
By their numbers in this assay, from the lowest: compound 3; then compounds 1, 2 and 4 (each within the scatter of the next).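

In this assay, the exchange of fluoro for chloro on the aromatic carbon is not neutral at every place on the ring: a 10-fold higher number from compound 3 to compound 4 (1.00 log units; beyond the scatter). The 4-chlorophenyl group also does not separate from the 3-substituted rings, with no change at the digits printed from compound 2 to compound 4 (within the scatter) and no change at the digits printed from compound 1 to compound 4 (within the scatter), so a halogen at the 4-position is not enough on its own, and among the compounds shown only the 4-fluorophenyl group of compound 3 stands apart. The outcome of this halogen exchange therefore depends on where it is made on the ring: the same change on two cores in this assay, no change at the digits printed (within the scatter) from compound 1 to compound 2 and a 10-fold lower number (1.00 log units; beyond the scatter) from compound 4 to compound 3, 10-fold (1.00 log units) apart, beyond the scatter of two such steps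

Going by these compounds, how a plain phenyl, a 4-bromophenyl or a 4-methoxyphenyl group would stand on the sulfonyl sulfur remains open. Also open, on these data alone, is whether the 4-fluorophenyl group would keep its lower number on a core with the methoxy group replaced by an amine or a carboxylic acid.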